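Isoxazole-substituted aminopyrazolopyrimidines: removing the phenyl

The compounds below may be only part of what the source reports. "The series", "measured", "known", "first", "only" and "open" are said of these compounds alone.

Measured compounds:
compound 1 `Nc1ncnc2c1c(-c1cc(C3CC3)on1)nn2C1CCCCC1` — 32500 nM
compound 2 `CC(C)n1nc(-c2cc(-c3ccccc3)on2)c2c(N)ncnc21` — 5720 nM
compound 3 `Nc1ncnc2c1c(-c1cc(C3CC3)on1)nn2C1CCOCC1` — 32900 nM

All three were run in an ADME assay on Nthy-ori 3-1 cells (Homo sapiens) for cytotoxicity, read by MTT assay, with a stated time of 10 days; on this read-out higher numbers stand for weaker inhibition of growth and lower numbers for stronger inhibition of growth. Compound 2 stands at the lowest number of the three; compound 1 and compound 3 both lie beyond the scatter above it. Among the measured compounds shown here, the one step available, a 1.0-fold higher number from compound 1 to compound 3 (0.01 log units; within the scatter), shows that exchanging the group on the aromatic nitrogen leaves the read-out unchanged.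

Compound 4 `CC(C)n1nc(-c2ccon2)c2c(N)ncnc21` is the next compound to be measured. It differs from compound 2 in one place: hydrogen in place of phenyl on an aromatic carbon. For the measured compounds named here, no measured step touches the group on the five-membered ring, so the step from compound 1 to compound 3 does not bear on it directly; it only shows that the nitrogen substituent is not where the series moves. Going by the values given here, what the values show is that compound 2, the only compound carrying the phenyl, gives the lowest number, while compound 1 and compound 3, which do not carry it, give higher numbers. Removing the phenyl altogether is therefore expected to raise the number, and compound 4 is estimated at 20000 nM (range 6000 nM to 60000 nM), meaning an expected step of a 3.5-fold higher number from compound 2 to compound 4 (0.54 log units; beyond the scatter).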

Compound 4, concentration for 50% growth inhibition: 18600 nM
Estimate against measurement, compound 4: 1.1-fold (0.03 log units) above, within the range that was stated.
By their numbers in this assay, from the lowest: compound 2; then compounds 4, 1 and 3 (each within the scatter of the next).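

In this assay, hydrogen in place of phenyl on this aromatic carbon, next to the ring oxygen, gives a 3.3-fold higher number from compound 2 to compound 4 (0.51 log units; beyond the scatter), so the lower number of compound 2 can now be tied to the phenyl with the rest of the structure held fixed. Compound 1 and compound 3 each differ from compound 2 in more than one place, so they could not assign the difference to this position alone, whereas this single change does, and its size lies beyond the scatter. Nothing in the available data explains why the phenyl has this effect on the read-out.

The compounds shown establish only the two ends of this position, phenyl and hydrogen, with the group on the aromatic nitrogen kept the same, and leave open how intermediate groups such as methyl or cyclopropyl would fall on that same background. They also leave open whether a phenyl bearing a carboxylic acid or an amine would retain the lower number of compound 2, and whether the phenyl step holds with cyclohexyl or oxan-4-yl on the aromatic nitrogen.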